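The source may hold more compounds than are shown below. What is called first, only, known or untested is meant among the compounds shown, and "the series" means these compounds.

Compound 1 `COc1ccccc1-c1cc(N2CCC(CNS(N)(=O)=O)CC2)ncn1`: > 100000 nM (a limit of the assay, not a number)
Compound 2 `NS(=O)(=O)NCC1CCN(c2cc(-c3ccccc3Cl)ncn2)CC1`: > 100000 nM (a limit of the assay, not a number)
Compound 3 `COc1ccccc1-c1cc(N2CCC(CCNS(N)(=O)=O)CC2)ncn1`: 74300 nM

All three were tested in a functional assay on HT-29 cells (Homo sapiens) for antiproliferative activity, read by sulforhodamine B assay, with a stated time of 48 h; a lower number here means a stronger inhibitor of growth, a higher number a weaker inhibitor of growth. Among the measured compounds shown here, compound 3 gives the only number; the other two values are limits. Compound 1 and compound 2 differ by chloro in place of methoxy on an aromatic carbon, and the step is a step that the two limits leave unreadable from compound 1 to compound 2 because both values sit at the limit of > 100000 nM in this assay, at which 2 of the 3 values shown sit. Lengthening the chain gives an at least 1.3-fold lower number from compound 1 to compound 3 (0.12 log units; that floor lies within the scatter).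

Compound 4 `NS(=O)(=O)NCCC1CCN(c2cc(-c3ccccc3Cl)ncn2)CC1` has not yet been measured in this assay. It carries the same change as that from compound 1 to compound 2, (chloro in place of methoxy on an aromatic carbon), on a core that differs from the core of compound 1 by (sulfamoylamino)methyl in place of sulfamoylamino on a saturated chain carbon bound to a saturated ring carbon. The earlier step being unreadable, the new one is expected to be small, resting on the number of compound 3, 74300 nM. Compound 4 is therefore expected to give about 90000 nM, likely between 40000 nM and 200000 nM, an expected step of a 1.2-fold higher number from compound 3 to compound 4 (0.08 log units; within the scatter), with a real chance that only a limit is returned.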

Compound 4, concentration for 50% growth inhibition: 52900 nM
Estimate against measurement, compound 4: 1.7-fold (0.23 log units) above; the range from low to high includes it.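

In this assay, chloro in place of methoxy gives a 1.4-fold lower number from compound 3 to compound 4 (0.15 log units; within the scatter), while the matching step on the shorter chain cannot be read, as both of its compounds sit at a limit of the assay. Lengthening the chain on the chloro core gives an at least 1.8-fold lower number from compound 2 to compound 4 (0.27 log units; that floor lies within the scatter). This gives a first look at the lengthening on two cores, but it does not show that the step carries over at the same size: the same change on two cores in this assay, an at least 1.3-fold lower number (0.12 log units; that floor lies within the scatter) from compound 1 to compound 3 and an at least 1.8-fold lower number (0.27 log units; that floor lies within the scatter) from compound 2 to compound 4; the limit leaves it open whether they differ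

The compounds shown leave open how a still longer chain, or an amine or a carboxylic acid in place of the sulfamoylamino group, would read in this assay. They also leave open what fluoro or methyl would give in place of chloro or methoxy.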